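The compounds below may be only part of what the source reports. "The series", "measured", "known", "first", "only" and "open" are said of these compounds alone.

Measured so far in an assay on HeLa cells for displacement of a labelled ligand from 5-hydroxytryptamine receptor 6 (Homo sapiens); on this read-out higher numbers stand for weaker inhibition and lower numbers for stronger inhibition:

compound 1 `O=S(=O)(c1ccc(F)cc1)c1cn(C2CCNC2)c2ncccc12` gives 8.5 nM
compound 2 `CN1CCC(n2cc(S(=O)(=O)c3ccc(F)cc3)c3cccnc32)C1` gives 5 nM
compound 3 `O=S(=O)(c1ccc(Cl)cc1)c1cn(C2CCCNC2)c2ncccc12` gives 7.6 nM

Compound 2 differs from compound 1 by methyl in place of hydrogen on an amine nitrogen in a ring, and this change gave a 1.7-fold lower number from compound 1 to compound 2 (0.23 log units; within the scatter). Compound 3 and compound 1 differ in more than one place; the difference between the two cores is not broken down here, and their two values lie within the scatter of each other.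

Compound 4 `CN1CCCC(n2cc(S(=O)(=O)c3ccc(Cl)cc3)c3cccnc32)C1` differs from compound 3 by methyl in place of hydrogen on an amine nitrogen in a ring. This is the same kind of change as from compound 1 to compound 2, not the same: there the amine nitrogen sits in a five-membered non-aromatic ring with 1 nitrogen, here in a six-membered non-aromatic ring with 1 nitrogen.

The step from compound 3 to compound 4 in this assay is expected to be a 1.5-fold lower number from compound 3 to compound 4 (0.18 log units; within the scatter), small because a 1.7-fold lower number from compound 1 to compound 2 (0.23 log units; within the scatter) stayed within the scatter. Compound 4 is expected to give 5 nM, with 2 nM to 12 nM as the likely range.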

Compound 4, inhibition constant: 11.5 nM
The estimate for compound 4 lay 2.3-fold (0.36 log units) below the measured number, within the range that was stated.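

Putting methyl in place of hydrogen on the amine nitrogen in the ring gave a 1.5-fold higher number from compound 3 to compound 4 (0.18 log units; within the scatter) in this assay. Set beside the earlier step, the change reads alike on the two cores, and the opposite directions of the two steps carry no weight: the same change on two cores in this assay, a 1.7-fold lower number (0.23 log units; within the scatter) from compound 1 to compound 2 and a 1.5-fold higher number (0.18 log units; within the scatter) from compound 3 to compound 4, 2.6-fold (0.41 log units) apart, within the scatter of two such steps. Among these compounds, this shows only that on neither core does the change move the number beyond the scatter; it does not show that the change is without effect on other cores, and it cannot separate ring size from the other differences between these two cores.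

The compounds shown carry only hydrogen or methyl on this nitrogen. Going by these compounds, what an ethyl group, a longer chain or an amide carbonyl would do there remains open.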